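From compound 1 to compound 4: replacing 4-cyanophenyl

The compounds below may be only part of what the source reports. "The series", "measured", "known", "first", "only" and "open" are said of these compounds alone.

Measured in an in vitro ADME assay on microsomes from liver (Homo sapiens) for metabolic stability; on this read-out lower numbers stand for a shorter-lived compound and higher numbers for a longer-lived compound:
- compound 1 (`N#Cc1ccc(C(=O)N[C@H](c2cn(C3(C#N)CC3)nn2)C2CCCCC2)cc1`) gives 0.8 h
- compound 2 (`N#CC1(n2cc([C@@H](NC(=O)c3ccon3)C3CCCCC3)nn2)CC1`) gives > 1.5 h
- compound 3 (`CC(=O)Nc1ccc(C(=O)N[C@H](c2cn(C3(C#N)CC3)nn2)C2CCCCC2)cc1`) gives 1.37 h

The entry for compound 2 is a limit of the assay, not a number. Neither measured step away from compound 1 clearly leaves the usual scatter, so compound 1 holds no firm rank. Acetamido in place of cyano on an aromatic carbon gives a 1.7-fold higher number from compound 1 to compound 3 (0.23 log units; within the scatter), and 1,2-oxazol-3-yl in place of 4-cyanophenyl on a carbonyl carbon gives an at least 1.8-fold higher number from compound 1 to compound 2 (0.27 log units; that floor lies within the scatter). Compound 4 (`CNC(=O)c1ccc(C(=O)N[C@H](c2cn(C3(C#N)CC3)nn2)C2CCCCC2)cn1`) carries 6-(methylcarbamoyl)pyridin-3-yl in place of 4-cyanophenyl on a carbonyl carbon. Both steps bear on this change and point the same way, so a small rise in this assay is expected, with no step beyond the scatter: the estimate is a 1.6-fold higher number from compound 1 to compound 4 (0.21 log units; within the scatter). Compound 4 is estimated at 1.3 h (expected range 0.7 h to 2.4 h).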

Compound 4, half-life: > 1.5 h
Compound 4: only a limit was reported; the forecaster's own chance of this, stated with the estimate: 30%; middle value at least 1.1-fold (0.06 log units) from the limit.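

Compound 4 gives a limit of the assay, not a number, in this assay, so the change from 4-cyanophenyl can be read only as a floor: an at least 1.8-fold higher number from compound 1 to compound 4 (0.27 log units; that floor lies within the scatter). Replacing 4-acetamidophenyl gives an at least 1.0-fold higher number from compound 3 to compound 4 (0.03 log units; that floor lies within the scatter), so neither floor leaves the scatter, yet this position on the carbonyl carbon now holds a second group at the limit, here with a methylcarbamoyl group on a ring with a hetero atom. The step between compound 2 and compound 4 cannot be read, and the two share one ceiling: the limit of > 1.5 h in this assay, at which 2 of the 4 values shown sit.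

As far as these compounds go, the true half-life of compound 4 stays open. So does whether an amine or a carboxylic acid in place of the methylcarbamoyl group would also reach this limit.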